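Hydrazone aryl swap: hydroxyl position and added methoxy

A few compounds are considered here, and "the series" means these few. Any claim that something is new, unique, unknown or untested is made for them only; others in the source may bear on it.

Measured compounds:
compound 1 `O=C(CSc1nnc(-c2ccncc2)o1)N/N=C/c1ccc(O)cc1` — 12200 nM
compound 2 `O=C(CSc1nnc(-c2ccncc2)o1)N/N=C/c1ccccc1O` — 7380 nM

Two compounds of the series have been run in a functional assay on SW 1116 cells (Homo sapiens) for cytotoxicity, read by MTT assay, with a stated time of 48 h; on this read-out higher numbers stand for weaker inhibition and lower numbers for stronger inhibition. Compound 2 stands at 7380 nM and compound 1 at 12200 nM; the two sit within the scatter of each other, so compound 2 cannot be set apart from compound 1 on these numbers.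

Compound 3 `COc1cc(/C=N/NC(=O)CSc2nnc(-c3ccncc3)o2)ccc1O` is still to be measured. It differs from compound 2 in one place: 4-hydroxy-3-methoxyphenyl in place of 2-hydroxyphenyl on a carbon with a double bond to nitrogen. Within the data shown here, the only measured step that bears on this is a 1.7-fold lower number from compound 1 to compound 2 (0.22 log units; within the scatter), which moved the hydroxyl around the same ring and stayed within the scatter. Among the measured compounds shown here, compound 3 returns the hydroxyl to the 4-position and adds a methoxy; no measured pair shows what an added methoxy does here, so that part is unsupported.

Given that compound 1 and compound 2 lie within the scatter, compound 3 is expected to give a number in this assay close to both, with the step of a 1.3-fold higher number from compound 2 to compound 3 (0.11 log units; within the scatter) expected to stay within the scatter. The estimate for compound 3 is 9500 nM, with a range from 3500 nM to 26000 nM.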

Compound 3, half-maximal inhibitory concentration: 3590 nM
Estimate against measurement, compound 3: 2.6-fold (0.42 log units) above; the measured number falls inside the stated range.
By their numbers in this assay, from the lowest: compound 3; then compounds 2 and 1 (each within the scatter of the next).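

In this assay, the group on a carbon with a double bond to nitrogen now gives a separation beyond the scatter, with a 2.1-fold lower number from compound 2 to compound 3 (0.31 log units; beyond the scatter) for 4-hydroxy-3-methoxyphenyl in place of 2-hydroxyphenyl. The more direct reading comes from methoxy in place of hydrogen on an aromatic carbon, a 3.4-fold lower number from compound 1 to compound 3 (0.53 log units; beyond the scatter), which keeps the hydroxyl of compound 1 and changes only the added group, whereas moving the hydroxyl alone gave only a 1.7-fold lower number from compound 1 to compound 2 (0.22 log units; within the scatter) and did not separate the two compounds. The step is therefore tied in these data to the added methoxy on the 4-hydroxyphenyl ring, although its size is modest and nothing available accounts for it.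

The compounds shown leave open whether the methoxy needs the hydroxyl in its compound 3 arrangement, as no 2-hydroxyphenyl ring carrying a methoxy appears among them. They also leave open whether an ethoxy in place of the methoxy, or an amine in place of the hydroxyl, would keep the lower number seen for compound 3 in this assay on this otherwise unchanged core.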